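The source may report more compounds than this note shows. Statements on the series, on what has been measured and on what is new or still open speak of the compounds shown alone.

Measured so far:
- Compound 1, `CC(C(=O)NCc1ccc(C(F)(F)F)nc1Nc1ccccc1)c1ccc(NS(C)(=O)=O)c(F)c1` — in a functional assay on CHO-K1 cells for antagonist activity at transient receptor potential cation channel subfamily V member 1 (Homo sapiens), read by FLIPR (a lower number here means a stronger inhibitor, a higher number a weaker inhibitor), compound 1 gives 59.6 nM.
- Compound 2, `CC(C(=O)NCc1ccc(C(F)(F)F)nc1N(C)c1ccccc1)c1ccc(NS(C)(=O)=O)c(F)c1` — in this assay compound 2 gives 0.9 nM.

Compound 2 holds the lower of the two numbers, and the gap to compound 1 is wide: a 66-fold lower number from compound 1 to compound 2 (1.82 log units; beyond the scatter). That single step shows how sensitive this part of the molecule is, since only a methyl placed on the ring-bound nitrogen separates the two compounds.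

Compound 3, `CC(C(=O)NCc1ccc(C(F)(F)F)nc1N1CCCC1)c1ccc(NS(C)(=O)=O)c(F)c1`, is the next compound to be measured. It differs from compound 2 in exactly one spot: pyrrolidin-1-yl in place of methyl(phenyl)amino on an aromatic carbon. The nitrogen keeps no hydrogen, so the change that mattered between compound 1 and compound 2 is not reversed. What does change is the group on that nitrogen, from an aromatic ring with a methyl to a small saturated ring. Among the measured compounds shown here, no measured step covers such a swap, so the direction is uncertain; the large step of a 66-fold lower number from compound 1 to compound 2 (1.82 log units; beyond the scatter) only warns that this position can move the number a great deal. A moderate loss is expected, an 8.9-fold higher number from compound 2 to compound 3 (0.95 log units; beyond the scatter), with compound 3 estimated at 8 nM, in the range 1.5 nM to 50 nM.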

Compound 3, inhibition constant: 0.6 nM
Estimate against measurement, compound 3: 13-fold (1.12 log units) above; the whole stated range lies above it.
By their numbers in this assay, from the lowest: compounds 3 and 2 (each within the scatter of the next); then compound 1.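

In this assay, the step to the pyrrolidin-1-yl group, a 1.5-fold lower number from compound 2 to compound 3 (0.18 log units; within the scatter), lies within the usual scatter, so compound 2 and compound 3 cannot be told apart. For this pair, then, the six-membered aromatic ring of carbon in methyl(phenyl)amino can give way to a five-membered non-aromatic ring with fewer heavy atoms without any readable change in the number. The step from the anilino group, a 99-fold lower number from compound 1 to compound 3 (2.00 log units; beyond the scatter), is large and beyond the scatter, so both compounds with no hydrogen on that nitrogen sit far from compound 1, although this step also swaps the group on the nitrogen, and the data offer no measurement that explains any of this.

The compounds shown leave open whether a larger saturated ring such as piperidine, or a morpholine ring carrying an oxygen, would behave like pyrrolidine here. They also leave open whether an open chain such as diethylamino would do the same, which would show whether a ring is needed on this nitrogen at all.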